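Chlorination of the shared core and tolerated concentration on lung cells

The source may hold more compounds than are shown below. What is called first, only, known or untested is meant among the compounds shown, and "the series" means these compounds.

Measured compounds:
compound 1 `ClCc1cccc(Cn2cnc3ncnc(Cl)c32)c1` — 52500 nM
compound 2 `ClCc1cccc(Cn2cnc3c(Cl)nc(Cl)nc32)c1` — 7080 nM

Among the compounds with values here, in a functional assay on HOP-92 cells (Homo sapiens) for cytotoxicity, read by sulforhodamine B assay, with a stated time of 48 h (a lower number here means that less compound is tolerated, a higher number that more compound is tolerated), compound 1 gives 52500 nM, the highest of the two numbers so far. Compound 2, carrying two chloro groups on the core, gives 7080 nM in this assay; the two values lie apart by more than the usual scatter, so compound 1 is the better tolerated of the pair. Within the data shown here, since compound 1 and compound 2 differ in more than one place, only their two values can be set side by side, and no single step is drawn between them.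

Compound 3 `ClCc1cccc(Cn2cnc3nc(Cl)nc(Cl)c32)c1` has not yet been measured in this assay. It differs from compound 1 by chloro in place of hydrogen on an aromatic carbon. The step from compound 1 to compound 3 in this assay is expected to be a drop, beyond the scatter, towards the region in which compound 2 sits with 7080 nM, giving an expected 4.8-fold lower number from compound 1 to compound 3 (0.68 log units; beyond the scatter). For compound 3 the estimate in this assay is 11000 nM, with a range from 3500 nM to 35000 nM.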

Compound 3, concentration lethal to 50% of the cells: 5240 nM
Beside the measured number, compound 3's estimate is 2.1-fold (0.32 log units) above it, and the stated range covers the measured number.
By their numbers in this assay, from the lowest: compounds 3 and 2 (each within the scatter of the next); then compound 1.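

In this assay, within the data shown here, chloro in place of hydrogen on the aromatic carbon between two ring nitrogen atoms gives a 10-fold lower number from compound 1 to compound 3 (1.00 log units; beyond the scatter), the only step so far that can be tied to a single place on the shared core. The carbon concerned lies meta to the chloro group already present in compound 1, so this step describes the addition of a second chloro group to the core, not a first. Nothing available explains the lower number, and no supporting measurement bears on this change.

The compounds shown leave open whether this step is specific to chloro, since an amine, a methoxy group or a fluoro group on the same aromatic carbon would be needed to separate that group from other replacements of hydrogen. They also leave open whether the step depends on the existing chloro group or on the chloromethyl group of the benzyl part, as both stay unchanged from compound 1 to compound 3.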